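Trimming the Amide Chain by One Carbon

The source may report more compounds than this note shows. Statements on the series, on what has been measured and on what is new or still open speak of the compounds shown alone.

Compound 2 `CCC(=O)NCc1cc2c(OC)cccc2[nH]1` gives 288 nM in an assay on NIH3T3 cells for binding affinity to melatonin receptor type 1B (Homo sapiens) (on this read-out lower numbers stand for stronger inhibition and higher numbers for weaker inhibition), the higher of the two numbers recorded so far. Within the data shown here, its only measured neighbour is compound 1 `CCC(=O)NCc1cc2c(OC)cccc2n1-c1ccccc1`, which gives 10.2 nM in this assay; that step, a 28-fold higher number from compound 1 to compound 2 (1.45 log units; beyond the scatter), came from hydrogen in place of phenyl on an aromatic nitrogen. Compound 3 `COc1cccc2[nH]c(CNC(C)=O)cc12` differs from compound 2 at another place: hydrogen in place of methyl on a saturated chain carbon bound to a carbonyl carbon, so that propanoylamino becomes acetamido. Among the measured compounds shown here, no measured step touches the amide chain, so nothing measured here anchors the size of the move from compound 2 to compound 3 in this assay. Only a small change, if any, is expected, so the step of a 1.4-fold higher number from compound 2 to compound 3 (0.14 log units; within the scatter) is estimated to fall close to the scatter. Compound 3 is therefore expected to give about 400 nM, within a range of 150 nM to 1200 nM.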

Compound 3, inhibition constant: 813 nM
Compound 3: middle estimate off by 2.0-fold (0.31 log units), on the low side, and the stated range covers the measured number.
By their numbers in this assay, from the lowest: compound 1; then compound 2; then compound 3.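

In this assay the swap of methyl for hydrogen on the saturated chain carbon bound to the carbonyl carbon, which turns propanoylamino into acetamido, gives a 2.8-fold higher number from compound 2 to compound 3 (0.45 log units; beyond the scatter) and so counts as a modest but real change. Among these compounds, this is the first measured step on the amide chain, and it shows that removing this one carbon weakens binding on this read-out rather than leaving it unchanged. No measurement at hand explains why the shorter chain gives the higher number.

As far as these compounds go, whether binding keeps improving as the chain grows remains open, since a longer chain such as butanoyl or a branched one such as isobutyryl would be needed to show where the gain stops. Also open, from the compounds shown here alone, is whether acetamido costs the same amount when phenyl sits on the aromatic nitrogen, as it does in compound 1.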